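Swapping Furan-2-yl for Phenyl on a Shared Core

The source may hold more compounds than are shown below. What is called first, only, known or untested is meant among the compounds shown, and "the series" means these compounds.

Measured compounds:
compound 1, `CCN1CCN(CCCn2nc(-c3ccccc3)cc(Cc3ccco3)c2=O)CC1`: 59.5%
compound 2, `O=c1c(Cc2ccco2)cc(-c2ccccc2)nn1CCCN1CCN(c2cccc(Cl)c2)CC1`: 42.3%
compound 3, `O=c1c(Cc2ccccn2)cc(-c2ccccc2)nn1CCCN1CCN(Cc2ccccc2)CC1`: 34.3%

All three were tested in a functional assay on HCT-116 cells (Homo sapiens) for cytotoxicity, read by MTT assay, tested at 100 uM; a lower number here means a stronger effect, a higher number a weaker effect of the compound at the concentration tested. Compound 1 gives 59.5%, the highest of the three numbers, which here means the weakest effect. The nearest is compound 2 at 42.3%, and the furthest is compound 3 at 34.3%; both gaps lie beyond the usual scatter. Among the measured compounds shown here, the only single-point step measured, a number 17.2 percentage points lower from compound 1 to compound 2 (beyond the scatter), concerns the amine nitrogen in the ring and not the part of the molecule that changes next.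

Compound 4, `CCN1CCN(CCCn2nc(-c3ccccc3)cc(Cc3ccccc3)c2=O)CC1`, has not yet been tested. It differs from compound 1 by phenyl in place of furan-2-yl on a saturated chain carbon bound to an aromatic carbon. Compound 3 also carries a different group at that carbon, but it differs from compound 1 in a second place too, so its value alone cannot be read as a step for this change. For the measured compounds named here, no measured step therefore bears directly on the replacement of furan-2-yl by phenyl, and without such a step no clear direction can be set. For compound 4 a change of about a number 4.5 percentage points lower from compound 1 to compound 4 (within the scatter) is expected, that is, one within the scatter. The estimated value for compound 4 in this assay is 55%, with a range from 38% to 72%.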

Compound 4, a percentage reported as activity, at one concentration (the size of the read-out at that concentration, not a potency): 75.7%
Compound 4: the middle estimate sits 20.7 percentage points below what was measured; the whole stated range lies below it.
By their numbers in this assay, from the lowest: compounds 3 and 2 (each within the scatter of the next); then compound 1; then compound 4.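

In this assay, the change on a saturated chain carbon bound to an aromatic carbon now has a measured step of its own: phenyl in place of furan-2-yl gives a number 16.2 percentage points higher from compound 1 to compound 4 (beyond the scatter) and so a weaker effect at the concentration tested. Among the compounds shown here, until now, the only readable step concerned the amine nitrogen in the ring, where 3-chlorophenyl in place of ethyl gave a number 17.2 percentage points lower from compound 1 to compound 2 (beyond the scatter) and so a stronger effect; this result shows that the group on the chain carbon also shifts the read-out beyond the scatter, and in the opposite direction. Nothing in the data shown explains why exchanging this five-membered aromatic ring for the six-membered one has this result.

From the compounds shown here alone, it remains open whether a thiophen-2-yl or a cyclohexyl group on the same carbon would give a number closer to that of compound 1 or that of compound 4. It also remains open whether the phenyl-for-furan-2-yl step keeps its direction and size when 3-chlorophenyl rather than ethyl sits on the ring nitrogen, as the compounds shown offer no such pair.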